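Aryl variation on an aromatic nitrogen: antiproliferative notes

The source may hold more compounds than are shown below. What is called first, only, known or untested is meant among the compounds shown, and "the series" means these compounds.

Compound 1 `COc1ccccc1-n1nncc1CN1C(=O)C2(C(C#N)=C(N)Oc3c(N)cc4nc5ccccc5nc4c32)c2ccccc21` — in an ADME assay on HUVEC cells (Homo sapiens) for antiproliferative activity, read by MTT assay, with a stated time of 48 h (on this read-out lower numbers stand for stronger inhibition and higher numbers for weaker inhibition), compound 1 gives > 50000 nM, a limit of the assay.
Compound 2 `CCOc1ccc(-n2nncc2CN2C(=O)C3(C(C#N)=C(N)Oc4c(N)cc5nc6ccccc6nc5c43)c3ccccc32)cc1` — in this assay compound 2 gives > 50000 nM, a limit of the assay.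
Compound 3 `Cc1ccc(-n2nncc2CN2C(=O)C3(C(C#N)=C(N)Oc4c(N)cc5nc6ccccc6nc5c43)c3ccccc32)cc1Cl` — in this assay compound 3 gives > 50000 nM, a limit of the assay.

Compound 3 stands only at a limit, as do the other two values shown (the limit of > 50000 nM in this assay, at which 3 of the 3 values shown sit). The change to compound 4 `COc1cc(-n2nncc2CN2C(=O)C3(C(C#N)=C(N)Oc4c(N)cc5nc6ccccc6nc5c43)c3ccccc32)c(OC)cc1Cl` is 4-chloro-2,5-dimethoxyphenyl in place of 3-chloro-4-methylphenyl on an aromatic nitrogen. Within the data shown here, the steps that bear on it are a step that the two limits leave unreadable from compound 1 to compound 3, a step that the two limits leave unreadable from compound 2 to compound 3 and a step that the two limits leave unreadable from compound 1 to compound 2; none of them can be read, as both ends of each sit at the limit (the limit of > 50000 nM in this assay, at which 3 of the 3 values shown sit). No size or direction follows from them, and in this assay no step beyond the scatter is expected, with compound 4 expected to sit at the limit again. Compound 4 is estimated at 50000 nM, within 20000 nM to 100000 nM. The expected step is a number no higher from compound 3 to compound 4 (the limit leaves the size open).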

Compound 4, half-maximal inhibitory concentration: > 50000 nM
Compound 4: only a limit was reported (the forecaster's own chance of this, stated with the estimate: 85%); the middle value lies on the limit itself.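

The steps from compound 4 to compound 1, compound 2 and compound 3 cannot be read in this assay, as all four compounds stand only at a limit: the limit of > 50000 nM in this assay, at which 4 of the 4 values shown sit.

The compounds shown leave open how far each lies beyond that limit and whether any aryl group on this aromatic nitrogen gives a measurable value in this assay.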